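Fluoro for ethyl on the core of compound 1

The source may hold more compounds than are shown below. What is called first, only, known or untested is meant among the compounds shown, and "the series" means these compounds.

In a functional assay on A-375 cells (Homo sapiens) for inhibition, read by CCK-8 assay, with a stated time of 72 h, tested at 2 uM (on this read-out higher numbers stand for more inhibition of growth at the one concentration tested and lower numbers for less inhibition of growth), compound 1 `CCc1ccc(SCc2ccc(C(=O)Nc3ccccc3N)cc2)cc1` gives 19.6%. Compound 2 `Nc1ccccc1NC(=O)/C=C/c1ccc(CSc2ccc(C(F)(F)F)cn2)cc1` gives 10.3%, which lies within the scatter of compound 1. Compound 3 `COC(=O)c1ccccc1SCc1ccc(C(=O)Nc2ccccc2N)cc1` gives 35.1%, beyond the scatter and on the higher side of compound 1. Compound 1 therefore sits at the low end of this small set, level with compound 2 and clearly short of compound 3.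

Compound 4 `Nc1ccccc1NC(=O)c1ccc(CSc2ccc(F)cc2)cc1` keeps the core of compound 1 and differs in one place: fluoro in place of ethyl on an aromatic carbon. This puts fluoro in place of ethyl on an aromatic carbon, para to a large group, turning the 4-ethylphenyl into a 4-fluorophenyl. Within the data shown here, no measured pair in this set isolates a single change, so the data give no direct size for this one. The expectation rests on compound 1 at 19.6% and assumes no shift beyond the scatter. The expected change is small, an estimated a number 2.4 percentage points higher from compound 1 to compound 4 (within the scatter), with no firm direction. For compound 4 the estimated value is 22%, with an expected range from 8% to 38%.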

Compound 4, percent growth inhibition at one concentration: 19.4%
Beside the measured number, compound 4's estimate is 2.6 percentage points above it; low and high end bracket the measured number.
By their numbers in this assay, from the lowest: compounds 2, 4 and 1 (each within the scatter of the next); then compound 3.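

In this assay, among these compounds, the change from 4-ethylphenyl to 4-fluorophenyl gives a number 0.2 percentage points lower from compound 1 to compound 4 (within the scatter), the first step in this set that isolates a single place. On an aromatic carbon para to a large group, fluoro in place of ethyl therefore cannot be told apart on this read-out, even though the fluoro group has fewer heavy atoms than the ethyl group. Nothing measured here bears on why the two groups read alike.

On these data alone, whether an amine, a carboxylic acid or a longer chain at this place would move the number beyond the scatter remains open. The compounds shown also leave open whether ethyl and fluoro would still read alike at a concentration other than the one tested.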